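A few compounds are considered here, and "the series" means these few. Any claim that something is new, unique, unknown or untested is made for them only; others in the source may bear on it.

In a functional assay on SF-268 cells (Homo sapiens) for antiproliferative activity, read by sulforhodamine B assay, with a stated time of 72 h (on this read-out lower numbers stand for stronger inhibition and higher numbers for weaker inhibition), compound 2 (`O=S(=O)(Nc1nccs1)c1ccc(Nc2nncc3ccccc23)cc1`) gives 45 nM and compound 1 (`O=S(=O)(Nc1ncccn1)c1ccc(Nc2nncc3ccccc23)cc1`) gives 34 nM so the two stand within the scatter of each other. Compound 3 (`O=S(=O)(Nc1ccccn1)c1ccc(Nc2nncc3ccccc23)cc1`) differs from compound 2 by pyridin-2-yl in place of 1,3-thiazol-2-yl on a sulfonamide nitrogen with pyridin-2-yl in place of 1,3-thiazol-2-yl on a sulfonamide nitrogen. Among the compounds with values here, the one measured step bearing on this exchange is a 1.3-fold higher number from compound 1 to compound 2 (0.12 log units; within the scatter) and it lies within the scatter, so no step beyond the scatter is expected in either direction in this assay here. The estimated change is a 1.1-fold lower number from compound 2 to compound 3 (0.05 log units; within the scatter) and it is expected to stay within the scatter. Compound 3 is expected at an estimated 40 nM (range 15 nM to 110 nM).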

Compound 3, half-maximal inhibitory concentration: 25 nM
The estimate for compound 3 lay 1.6-fold (0.20 log units) above the measured number, and the stated range covers the measured number.
By their numbers in this assay, from the lowest: compounds 3, 1 and 2 (each within the scatter of the next).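

In this assay, pyridin-2-yl on a sulfonamide nitrogen gives a 1.8-fold lower number from compound 2 to compound 3 (0.26 log units; within the scatter) against 1,3-thiazol-2-yl and a 1.4-fold lower number from compound 1 to compound 3 (0.13 log units; within the scatter) against pyrimidin-2-yl. All three aromatic groups at this place therefore stand within the scatter of each other, and a five-membered ring is not told apart from a six-membered one on this read-out. Nothing given here accounts for this result. The compounds shown leave open whether a cyclohexyl ring or a longer alkyl chain on this nitrogen would stay within that same scatter.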